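The source may hold more compounds than are shown below. What is called first, only, known or untested is meant among the compounds shown, and "the series" means these compounds.

Compound 1, `CC[C@@H](Nc1c(C#N)c(-c2ccc(-c3cccnc3C)cc2)nc2cnccc12)C(N)=O`: 1.9 in a physicochemical assay for lipophilicity, read by HPLC, at pH 7.5; on this read-out lower numbers stand for lower lipophilicity and higher numbers for higher lipophilicity.
Compound 2, `CC(C)(CC(N)=O)c1c(C#N)c(-c2ccc(Br)cc2)nc2cnccc12`: 2.1 in this assay.

Among the measured compounds shown here, compound 1 and compound 2 lie within the usual scatter of each other in this assay, and no step between them has been worked out, so the two numbers give no direction for the series yet.

Compound 3, `CC[C@@H](Nc1c(C#N)c(-c2ccc(-c3cccc(C)c3F)cc2)nc2cnccc12)C(N)=O`, has not been measured in this assay. It differs from compound 1 in one place: 2-fluoro-3-methylphenyl in place of 2-methylpyridin-3-yl on an aromatic carbon. The group that leaves carries one hydrogen-bond acceptor; the group that enters carries none. For the measured compounds named here, no measured pair of this kind exists to anchor the size. An upward step beyond the scatter is expected, estimated at a number 0.80 log units higher from compound 1 to compound 3 (beyond the scatter). Compound 3 is estimated at 2.7, in the range 2.3 to 3.1.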

Compound 3, distribution coefficient: 3
Estimate against measurement, compound 3: 0.30 log units below; low and high end bracket the measured number.
By their numbers in this assay, from the lowest: compounds 1 and 2 (each within the scatter of the next); then compound 3.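

Among the compounds shown here, on an aromatic carbon para to a large group, 2-fluoro-3-methylphenyl in place of 2-methylpyridin-3-yl gives the first step that can be read in this assay: a number 1.10 log units higher from compound 1 to compound 3 (beyond the scatter). This position can therefore move the read-out well beyond the scatter, with a large step upward for this change. Nothing at hand ties the step to a cause.

Still open, going by these compounds, is whether the step follows the loss of the ring nitrogen or the gain of the fluorine. Also open, on these data alone, is how a phenyl carrying an amine or a carboxylic acid would read at this position.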